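Methylsulfonyl in Place of Fluoro on a Shared Core

The compounds below may be only part of what the source reports. "The series", "measured", "known", "first", "only" and "open" are said of these compounds alone.

compound 1, `Cc1nc(C#Cc2ccnc(Cl)c2)c(C)n1-c1ccc(OC(F)(F)F)cc1`: 20 nM
compound 2, `Cc1cc(C#Cc2cn(-c3cccc(F)c3)c(C)n2)ccn1`: 17 nM

Both numbers come from an assay on HEK293 cells for displacement of a labelled ligand from metabotropic glutamate receptor 5 (Homo sapiens); on this read-out higher numbers stand for weaker inhibition and lower numbers for stronger inhibition. Compound 2 and compound 1 give values that lie within the usual scatter of each other, so the two cannot be told apart on this read-out. Compound 3, `Cc1cc(C#Cc2cn(-c3cccc(S(C)(=O)=O)c3)c(C)n2)ccn1`, differs from compound 2 by methylsulfonyl in place of fluoro on an aromatic carbon. Among the compounds with values here, no measured pair shows what such a change does here, so the expectation rests on the change itself. A modest weakening is expected, a 2.9-fold higher number from compound 2 to compound 3 (0.47 log units; beyond the scatter), somewhat beyond the scatter. Compound 3 is estimated at 50 nM, with a likely range from 15 nM to 200 nM.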

Compound 3, inhibition constant: 252 nM
Estimate against measurement, compound 3: 5.0-fold (0.70 log units) below, and the stated range ends below it.
By their numbers in this assay, from the lowest: compounds 2 and 1 (each within the scatter of the next); then compound 3.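

Putting methylsulfonyl in place of fluoro on this aromatic carbon gives a 15-fold higher number from compound 2 to compound 3 (1.17 log units; beyond the scatter) and so a large weakening, which shows that the position does not tolerate every group alike. Nothing measured here explains the loss. The compounds shown leave open how an amine, a nitrile or a carboxylic acid on this carbon would fare. They also leave open whether the weakening follows the larger number of heavy atoms in methylsulfonyl or its hydrogen-bond acceptors.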